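From compound 2 to compound 3: working notes

This account rests on a few compounds, and the source may have more. Where it says the series, first, only, none or still open, it means among the compounds named here.

Measured so far in an ADME assay on P388D1 cells (Mus musculus) for cytotoxicity, read by fluorescence and resazurin assay, with a stated time of 72 h; on this read-out lower numbers stand for stronger inhibition and higher numbers for weaker inhibition:
Compound 1 `O=C(Nc1ncc(Cc2ccncc2)s1)C1CCCCC1` gives "not determined" (no result reported)
Compound 2 `O=C(Nc1ncc(Cc2cccc3c2CCC3)s1)C1CCCCC1` gives > 40000 nM

In this assay compound 2 gives > 40000 nM, which is a limit and not a number. For the measured compounds named here, the series so far offers the limit of > 40000 nM in this assay, at which 1 of the 2 values shown sits, and no other reading. Going by the values given here, compound 1 has no reported result, so the data hold no measured step from which a size could be taken.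

Compound 3 `O=C(CCC1CCCCC1)Nc1ncc(Cc2cccc3c2CCC3)s1` keeps the core of compound 2 and carries 2-cyclohexylethyl in place of cyclohexyl on a carbonyl carbon. The ring stays the same, and the change lies in the chain that now links it to the carbonyl carbon.

In this assay no change beyond the usual scatter is expected, and any small shift is expected towards stronger inhibition. The only anchor for this expectation is compound 2 with > 40000 nM, a limit. The estimated change is an at least 1.1-fold lower number from compound 2 to compound 3 (0.05 log units; that floor lies within the scatter). Compound 3 may well give only a limit. For compound 3 the expected half-maximal inhibitory concentration is 35000 nM, with an estimated range from 12000 nM to 60000 nM.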

Compound 3, half-maximal inhibitory concentration: > 40000 nM
Compound 3 was reported as a limit; the forecaster's own chance of this, stated with the estimate: 65%; middle value at least 1.1-fold (0.05 log units) from the limit.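

In this assay, compound 2 and compound 3 are both reported only as limits, so no step from one to the other can be read: the limit of > 40000 nM in this assay, at which 2 of the 3 values shown sit.

The compounds shown leave open whether 2-cyclohexylethyl in place of cyclohexyl on a carbonyl carbon shifts the half-maximal inhibitory concentration at all in this assay.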